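Shorter amine chain on a bromo and a chloro core

This account rests on a few compounds, and the source may have more. Where it says the series, first, only, none or still open, it means among the compounds named here.

The measured compounds are:
compound 1, `CN(C)CN1C(=O)C(=O)c2c(Br)cccc21`, with 49000 nM;
compound 2, `CCN(CC)CN1C(=O)C(=O)c2c(Br)cccc21`, with 11700 nM;
compound 3, `CCN(CC)CN1C(=O)/C(=N\c2nc3ccc(C)cc3s2)c2c(Cl)cccc21`, with 27300 nM.

All three were tested in a functional assay on MDA-MB-468 cells (Homo sapiens) for cytotoxicity, read by sulforhodamine B assay, with a stated time of 48 h; on this read-out higher numbers stand for weaker inhibition of growth and lower numbers for stronger inhibition of growth. Compound 2 gives 11700 nM, and compound 1, which differs from it by dimethylamino in place of diethylamino on a saturated chain carbon bound to an amide-type nitrogen in a ring, gives 49000 nM; the step is a 4.2-fold higher number from compound 2 to compound 1 (0.62 log units; beyond the scatter). Compound 3 shares the (diethylamino)methyl chain with compound 2 but carries a different core; the difference between the two cores is not broken down here. In this assay compound 3 gives 27300 nM.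

Compound 4, `Cc1ccc2nc(/N=C3\C(=O)N(CN(C)C)c4cccc(Cl)c43)sc2c1`, has not yet been measured. It differs from compound 3 by dimethylamino in place of diethylamino on a saturated chain carbon bound to an amide-type nitrogen in a ring, which is the same change as that from compound 2 to compound 1. Because that step was a 4.2-fold higher number from compound 2 to compound 1 (0.62 log units; beyond the scatter), the expectation is that the number rises again from compound 3 to compound 4, and the step is estimated as a 3.3-fold higher number from compound 3 to compound 4 (0.52 log units; beyond the scatter). The estimate rests on a single measured pair on a different core, so it carries a wide range. Compound 4 is therefore expected to give about 90000 nM in this assay, with the likely range running from 35000 nM to 250000 nM.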

Compound 4, concentration for 50% growth inhibition: 28100 nM
Compound 4: middle estimate off by 3.2-fold (0.51 log units), on the high side; the measured number lies below the stated range.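

In this assay, dimethylamino in place of diethylamino on a saturated chain carbon bound to an amide-type nitrogen in a ring gives a 1.0-fold higher number from compound 3 to compound 4 (0.01 log units; within the scatter), so on this core the two compounds stand within the scatter of each other. The change therefore does not carry over with the same size from the core of compound 2 to the core of compound 3, and the step measured on one core would not have served as a reliable guide to the other: the same change on two cores in this assay, a 4.2-fold higher number (0.62 log units; beyond the scatter) from compound 2 to compound 1 and a 1.0-fold higher number (0.01 log units; within the scatter) from compound 3 to compound 4, 4.1-fold (0.61 log units) apart, beyond the scatter of two such steps

Going by these compounds alone, this does not show which feature of the cores goes with the gap, since they differ in more than one place and each core is represented by only one pair; nor does it show how the change would behave on a third core.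

The compounds shown leave open whether a cyclic amine such as piperidine or morpholine in place of diethylamino would also give steps that differ from one core to the other. They also leave open how a longer chain carrying the amine would read on these cores, and whether a bromo core bearing the substituent found on compound 3 would follow compound 2 or compound 4.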